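The compounds below may be only part of what the source reports. "The series", "measured", "known", "first", "only" and "open" are said of these compounds alone.

Compound 3, `CCNC(=O)Nc1cccc2c1CN(C)CC2c1ccccc1`, is the compound whose number is highest of the two numbers available in a functional assay on the whole organism for inhibition, with Mus musculus as the target (a lower number here means that less compound is needed, a higher number that more compound is needed for the effect), where compound 3 gives 80 mg/kg. The nearest number belongs to compound 1, `CN1Cc2c(N)cccc2C(c2ccc(Cl)cc2)C1`, which in this assay gives 1.6 mg/kg. Compound 2, `CC(C)c1ccc(C2CN(C)Cc3c(N)cccc32)cc1`, reaches only a limit of the assay, as compound 2 in this assay gives > 80 mg/kg; this is the case described by the limit of > 80 mg/kg in this assay, at which 1 of the 3 values shown sits.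

Compound 4, `CC(C)NCCC(=O)Nc1cccc2c1CN(C)CC2c1ccccc1`, is not yet measured. It differs from compound 3 in one place: 2-(isopropylamino)ethyl in place of ethylamino on a carbonyl carbon. Among the compounds with values here, no measured step touches the group on the carbonyl carbon. Within the data shown here, the only measured step, an at least 50-fold higher number from compound 1 to compound 2 (1.69 log units; beyond the scatter), concerns a different place, the aromatic carbon, and so gives no guide to the size or direction of the present change.

Among the measured compounds shown here, with no step bearing on it, the expectation for compound 4 is a number close to that of compound 3, with the step of a 1.3-fold lower number from compound 3 to compound 4 (0.12 log units; within the scatter) estimated as within the scatter. Compound 4 is therefore expected to give about 60 mg/kg in this assay, estimated to lie between 20 mg/kg and 150 mg/kg.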

Compound 4, dose for half-maximal effect: 150 mg/kg
Estimate against measurement, compound 4: 2.5-fold (0.40 log units) below; measured number inside the range.
By their numbers in this assay, from the lowest: compound 1; then compounds 3 and 4 (each within the scatter of the next).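

Within the data shown here, exchanging ethylamino for 2-(isopropylamino)ethyl on a carbonyl carbon gives the first measured step at this place in this assay: a 1.9-fold higher number from compound 3 to compound 4 (0.27 log units; within the scatter). The earlier step, at the aromatic carbon, lay beyond the scatter, whereas this change, which enters more heavy atoms and one more hydrogen-bond acceptor, does not separate the two compounds. Within this single pair, the group on the carbonyl carbon can therefore be exchanged without a readable difference in the number, although one pair cannot show how far that holds.

Going by these compounds, whether a carboxylic acid, a piperidine or a longer chain on the same carbonyl carbon would shift the number remains open. Compound 2 remains a limit and not a number: the limit of > 80 mg/kg in this assay, at which 1 of the 4 values shown sits.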